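This account rests on a few compounds, and the source may have more. Where it says the series, first, only, none or still open, it means among the compounds named here.

Among the compounds with values here, in a physicochemical assay for lipophilicity, measured as octanol-water partition, at pH 7.4 (on this read-out lower numbers stand for lower lipophilicity and higher numbers for higher lipophilicity), compound 1 `Cc1ccc2[nH]c(C(=O)N[C@H]3CN(S(=O)(=O)c4ccccc4)C[C@@H]3C(=O)NCCN(C)C)cc2c1` gives 2.1 and compound 2 `Cc1ccc2[nH]c(C(=O)N[C@H]3CN(S(=O)(=O)c4ccnc(C)c4)C[C@@H]3C(=O)NCCN(C)C)cc2c1` gives 1.7 as the lower of the two numbers so far. Compound 3 `Cc1ccc2[nH]c(C(=O)N[C@H]3CN(S(=O)(=O)C4CCOCC4)C[C@@H]3C(=O)NCCN(C)C)cc2c1` differs from compound 2 by oxan-4-yl in place of 2-methylpyridin-4-yl on a sulfonyl sulfur with oxan-4-yl in place of 2-methylpyridin-4-yl on a sulfonyl sulfur. Within the data shown here, the only measured step at this sulfur, with 2-methylpyridin-4-yl in place of phenyl, is a number 0.40 log units lower from compound 1 to compound 2 (beyond the scatter) and it is modest. Among the measured compounds shown here, no measured step involves oxan-4-yl. Resting on a number 0.40 log units lower from compound 1 to compound 2 (beyond the scatter) alone, a small further fall in this assay is expected for compound 3. The expected change is a number 0.20 log units lower from compound 2 to compound 3 (within the scatter) and may stay within the scatter. Compound 3 is estimated at 1.5 within an expected range of 1.1 to 1.9 on this read-out.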

Compound 3, distribution coefficient: 1
For compound 3 the middle estimate is 0.50 log units above the measured one, and the stated range ends above it.
By their numbers in this assay, from the lowest: compound 3; then compound 2; then compound 1.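

Within the data shown here, on the sulfonyl sulfur in this assay, oxan-4-yl in place of 2-methylpyridin-4-yl gives a further fall (a number 0.70 log units lower from compound 2 to compound 3 (beyond the scatter)), and oxan-4-yl in place of phenyl gives the first large step at this position (a number 1.10 log units lower from compound 1 to compound 3 (beyond the scatter)). The position therefore spans a wider range than compound 1 and compound 2 showed, and a non-aromatic ring now stands at its low end. No evidence on the cause of these steps is available. Still open, going by these compounds, is whether the ring oxygen of oxan-4-yl or the loss of the aromatic ring carries the fall. A cyclohexyl group on the sulfonyl sulfur would separate the two.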